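The compounds below may be only part of what the source reports. "The series", "measured", "known", "first", "only" and "open" are said of these compounds alone.

Compound 1 `O=c1n(Cc2nc3nc(Cl)ccc3n2CCCCF)c2cnccc2n1C1CC1` was tested in an ADME assay on HeLa cells (Homo sapiens) for cytotoxicity, read by ATP content, with a stated time of 3 days; on this read-out higher numbers stand for lower toxicity in this test and lower numbers for higher toxicity in this test. In this assay compound 1 gives > 50000 nM, which is a limit of the assay rather than a measured number. Compound 2 `O=c1n(Cc2cc3cnccc3n2CCCCF)c2cnccc2n1C1CC1` in this assay gives > 50000 nM, again a limit. Compound 3 `N#CCCCn1c(Cn2c(=O)n(-c3ccncn3)c3ccncc32)cc2cc(Cl)ccc21` in this assay gives > 50000 nM, also a limit. So compound 1 stands where the other two stand: the limit of > 50000 nM in this assay, at which 3 of the 3 values shown sit.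

Compound 4 `N#CCCCn1c(Cn2c(=O)n(C3CC3)c3ccncc32)nc2nc(Cl)ccc21` has not yet been measured in this assay. It differs from compound 1 in one place: cyano in place of fluoromethyl on a saturated chain carbon, three bonds along the chain from an aromatic nitrogen. Among the measured compounds shown here, no step between two measured compounds is available here, so no measured step guides the expectation. Because compound 1 gives > 50000 nM in this assay, compound 4 is expected to sit at that limit as well, with no step beyond the scatter in either direction. The estimate for compound 4 in this assay is 50000 nM, with a range from 25000 nM to 100000 nM. The expected step is a number no higher from compound 1 to compound 4 (the limit leaves the size open).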

Compound 4, half-maximal cytotoxic concentration: > 50000 nM
Compound 4: no number, only a limit; the forecaster's own chance of this, stated with the estimate: 85%; the middle value lies on the limit itself.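

Among the compounds shown here, compound 1 and compound 4 both sit at a limit of the assay rather than at a number, so no step between them can be read: the limit of > 50000 nM in this assay, at which 4 of the 4 values shown sit.

The compounds shown leave open whether swapping fluoromethyl for cyano changes the result in this assay at all, and at what concentration any of them turns toxic.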